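A few compounds are considered here, and "the series" means these few. Any claim that something is new, unique, unknown or untested is made for them only; others in the source may bear on it.

Of the compounds shown here, three built on one shared core have been tested in an assay on isolated protein for inhibition of Maltase-glucoamylase (Homo sapiens), with a stated time of 15 min; a lower number here means a stronger inhibitor, a higher number a weaker inhibitor. Compound 1 `O=C(N/N=C/c1cccs1)c1ccc(-c2nc3ccccc3s2)cc1` gives 8480 nM, compound 2 `COc1ccc(/C=N/NC(=O)c2ccc(-c3nc4ccccc4s3)cc2)c(O)c1` gives 6970 nM, and compound 3 `O=C(N/N=C/c1ccc([N+](=O)[O-])cc1)c1ccc(-c2nc3ccccc3s2)cc1` gives 26400 nM, the highest of the three numbers, which makes compound 3 the weakest inhibitor of this small set. Compound 4 `COc1ccc(/C=N/NC(=O)c2ccc(-c3nc4ccccc4s3)cc2)cc1` differs from compound 3 in one place: methoxy in place of nitro on an aromatic carbon. Because a 3.1-fold higher number from compound 1 to compound 3 (0.49 log units; beyond the scatter) and a 3.8-fold higher number from compound 2 to compound 3 (0.58 log units; beyond the scatter) both raised the number modestly when the 4-nitrophenyl came in, taking the nitro away again is expected to bring the number back down by a modest step in this assay, a 3.3-fold lower number from compound 3 to compound 4 (0.52 log units; beyond the scatter). Compound 4 is therefore estimated at 8000 nM, with a likely range from 4000 nM to 16000 nM.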

Compound 4, half-maximal inhibitory concentration: 18300 nM
Beside the measured number, compound 4's estimate is 2.3-fold (0.36 log units) below it; the whole stated range lies below it.
By their numbers in this assay, from the lowest: compounds 2 and 1 (each within the scatter of the next); then compounds 4 and 3 (each within the scatter of the next).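

Putting methoxy in place of nitro gives a 1.4-fold lower number from compound 3 to compound 4 (0.16 log units; within the scatter) in this assay and so these two groups cannot be told apart at this position. Taking away the hydroxy gives a 2.6-fold higher number from compound 2 to compound 4 (0.42 log units; beyond the scatter) and 4-methoxyphenyl in place of thiophen-2-yl gives a 2.2-fold higher number from compound 1 to compound 4 (0.33 log units; beyond the scatter) so compound 4 stays separated from both by more than the scatter. Still open, going by these compounds, is whether an amine or a carboxylic acid at this position would separate from methoxy and nitro. Nothing measured here explains these differences.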